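Swapping an aryl for a sulfonyl on the piperazine nitrogen

A few compounds are considered here, and "the series" means these few. Any claim that something is new, unique, unknown or untested is made for them only; others in the source may bear on it.

Of the compounds shown here, three with a shared core have been tested in an in vitro assay on U2OS cells for agonist activity at neurotensin receptor type 2 (Homo sapiens), read by reporter gene assay and beta-arrestin recruitment (on this read-out lower numbers stand for an effect already at smaller amounts and higher numbers for an effect only at larger amounts of compound), and none of them gave a number. Compound 1 `COc1cc2nc(C3CCC3)nc(N3CCN(c4ccccc4F)CC3)c2cc1OC` reached only the limit of > 80000 nM. Compound 2 `COc1ccc2nc(C3CC3)nc(N3CCN(c4ccccc4OC)CC3)c2c1` likewise stayed at the limit of > 80000 nM. Compound 3 `CCOc1ccccc1N1CCN(c2nc(C3CC3)nc3cc(OC)c(OC)cc23)CC1`, the starting point of the step followed here, also gave only the limit of > 80000 nM. Compound 3 therefore cannot be placed against the other two on a scale, since the limit of > 80000 nM in this assay, at which 3 of the 3 values shown sit, summarises the whole picture so far.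

Compound 4 `COc1cc2nc(C3CC3)nc(N3CCN(S(=O)(=O)c4ccccc4)CC3)c2cc1OC` is the next compound to be measured in this assay. Compared with compound 3 it carries phenylsulfonyl in place of 2-ethoxyphenyl on an amine nitrogen in a ring. For the measured compounds named here, no step between two measured compounds exists that would show how such a change acts in this assay, so the expectation rests on the shared outcome alone. Going by the values given here, since every value so far sits at the limit, the step from compound 3 to compound 4 is expected to be a number no higher from compound 3 to compound 4 (the limit leaves the size open), most likely nothing beyond the scatter and again ending at a limit. For compound 4 the estimate in this assay is 80000 nM, with a range from 20000 nM to 300000 nM.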

Compound 4, half-maximal effective concentration: > 80000 nM
Compound 4 gave a limit, no number; the forecaster's own chance of this, stated with the estimate: 85%; the middle value sits exactly at the limit.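

Compound 3 and compound 4 both ended at a limit in this assay, so no step can be read between them. The compounds shown leave open which change, if any, would give a measurable value, and the whole picture remains: the limit of > 80000 nM in this assay, at which 4 of the 4 values shown sit.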